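A few compounds are considered here, and "the series" means these few. Any claim that something is new, unique, unknown or untested is made for them only; others in the source may bear on it.

Compound 1 `COc1nc(-c2ccsc2)ccc1[C@@H](c1ccccc1)[C@@](O)(CCN(C)C)c1cccc2ccccc12` is one of three compounds examined in a toxicity assay on HeLa cells (Homo sapiens) for cytotoxicity; a higher number here means that more compound is tolerated, a lower number that less compound is tolerated. For compound 1 the result is a limit of the assay rather than a number: in this assay compound 1 gives > 64 ug/mL. This is the limit of > 64 ug/mL in this assay, at which 1 of the 3 values shown sits, which fixes where compound 1 stands only loosely. Compound 2 `COc1ncc(-c2ccccc2)cc1[C@@H](c1ccccc1)[C@@](O)(CCN(C)C)c1cc(F)ccc1F` has no result in this assay, its entry being "nd" (no result reported). Within the data shown here, compound 3 `COc1ncc(-c2ccccc2)cc1[C@@H](c1ccccc1)[C@@](O)(CCN(C)C)c1ccccc1` is the only one with a number, and in this assay compound 3 gives 11.9 ug/mL. No pair of measured compounds differing in a single place is available, and the effect of any one change on this read-out is not known from the three compounds shown.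

Compound 4 `COc1nc(-c2ccc(OC(F)(F)F)cc2)ccc1[C@@H](c1ccccc1)[C@@](O)(CCN(C)C)c1cccc2ccccc12` has not yet been measured. It differs from compound 1 in one place: 4-(trifluoromethoxy)phenyl in place of thiophen-3-yl on an aromatic carbon. The value of compound 1 is only a limit, and no measured step size is available. The expectation is that compound 4 tolerates somewhat less compound than compound 1, with a fair chance that it too comes back as a limit. For compound 4 the expected value in this assay is 30 ug/mL, within a range from 8 ug/mL to 64 ug/mL. The step this expectation means, an at least 2.1-fold lower number from compound 1 to compound 4 (0.32 log units; beyond the scatter), is an estimate and not a measurement.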

Compound 4, half-maximal cytotoxic concentration: > 64 ug/mL
Compound 4: a limit, no number (the forecaster's own chance of this, stated with the estimate: 35%); at least 2.1-fold (0.32 log units) between middle value and limit.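

In this assay compound 1 and compound 4 both end at a limit of the assay rather than a number, so no step between them can be read: the limit of > 64 ug/mL in this assay, at which 2 of the 4 values shown sit.

The compounds shown leave open how far either compound lies beyond that limit, and whether 4-(trifluoromethoxy)phenyl in place of thiophen-3-yl changes the amount tolerated at all.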